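The compounds below may be only part of what the source reports. "The series", "measured", "known", "first", "only" and "open" are said of these compounds alone.

Two compounds that share one core have been run in a functional assay on Raji cells (Homo sapiens) for inhibition, read by MTT assay, with a stated time of 48 h; on this read-out lower numbers stand for stronger inhibition and higher numbers for weaker inhibition. Compound 1 `C=CC(=O)Nc1cccc(Nc2ncnc3ccc(-c4ccc(F)nc4)cc23)c1` returns > 50000 nM in this assay, which is a limit of the assay and not a number, the situation described by the limit of > 50000 nM in this assay, at which 1 of the 2 values shown sits. Compound 2 `C=CC(=O)Nc1cccc(Oc2ncnc3ccc(-c4ccc(F)nc4)cc23)c1` returns 11000 nM in this assay. Within the data shown here, on the values recorded, compound 2 therefore holds the only actual number; the other result is a limit, so no ordering between the two can be drawn from it, and only what the two values show can be said.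

Compound 3 `C=CC(=O)Nc1cccc(Oc2ncnc3ccc(-c4cnc5ccccc5c4)cc23)c1` differs from compound 2 in one place: quinolin-3-yl in place of 6-fluoropyridin-3-yl on an aromatic carbon. Among the measured compounds shown here, no measured step between compounds carrying this change is available, so its size cannot be read off from a pair already tested. The expectation is a step toward stronger inhibition of modest size, with a real chance that the change stays within the scatter of this assay.

For compound 3 the estimated result is 5000 nM, with a range from 1500 nM to 20000 nM, which corresponds to an expected step of a 2.2-fold lower number from compound 2 to compound 3 (0.34 log units; beyond the scatter).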

Compound 3, half-maximal inhibitory concentration: 8600 nM
For compound 3 the middle estimate is 1.7-fold (0.24 log units) below the measured one; the range from low to high includes it.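

Putting quinolin-3-yl in place of 6-fluoropyridin-3-yl on this aromatic carbon gives, in this assay, a 1.3-fold lower number from compound 2 to compound 3 (0.11 log units; within the scatter), so the two compounds cannot be told apart on this read-out. The earlier compounds shown here said nothing about the group at this position, and this pair now shows that the place, para to a fused ring, takes a second six-membered aromatic ring, with 10 heavy atoms in place of 7, with no separation from compound 2 beyond the scatter. Nothing measured here gives a reason for this result.

As far as these compounds go, whether an amine, a carboxylic acid or a longer chain on this aromatic carbon would move the number beyond the scatter remains open, since both groups compared here are aromatic rings with one ring nitrogen. Compound 1 stands at a limit of the assay and not at a number, and what quinolin-3-yl would do on its core also stays open: the limit of > 50000 nM in this assay, at which 1 of the 3 values shown sits.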